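The compounds below may be only part of what the source reports. "The series", "measured", "known", "first", "only" and "open" are said of these compounds alone.

The three measured compounds share one core and differ only in the group carried on an aromatic carbon of that core. Compound 1 `O=c1[nH]c(=O)n([C@H]2C[C@H](O)[C@@H](CO)O2)cc1/C=C/I` carries 2-iodoethenyl there; in an ADME assay on L1210/0 cells (Mus musculus) for cytotoxicity, with a stated time of 48 h (a lower number here means a stronger inhibitor, a higher number a weaker inhibitor), compound 1 gives 63900 nM. Compound 2 `O=C(CI)NCc1cn([C@H]2C[C@H](O)[C@@H](CO)O2)c(=O)[nH]c1=O` carries (((iodomethyl)carbonyl)amino)methyl, and in this assay compound 2 gives 107000 nM. Compound 3 `O=c1[nH]c(=O)n([C@H]2C[C@H](O)[C@@H](CO)O2)cc1C#CCCCO` carries 5-hydroxypent-1-yn-1-yl. For compound 3 this assay reports only a limit, > 200000 nM, which is the limit of > 200000 nM in this assay, at which 1 of the 3 values shown sits. Within the data shown here, compound 3 is thus the one compound without a definite number: an at least 3.1-fold higher number from compound 1 to compound 3 (0.49 log units; beyond the scatter), while an at least 1.8-fold higher number from compound 2 to compound 3 (0.27 log units; that floor lies within the scatter).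

Compound 4 `CCC#Cc1cn([C@H]2C[C@H](O)[C@@H](CO)O2)c(=O)[nH]c1=O` differs from compound 3 in one place: hydrogen in place of hydroxymethyl on a saturated chain carbon, two bonds along the chain from a triple-bonded carbon. Among the measured compounds shown here, no measured step removes a hydroxymethyl; the two steps that lead to compound 3 concern the whole 5-hydroxypent-1-yn-1-yl group, one beyond the scatter and one within it. With nothing pointing the other way, compound 4 is expected to stay close to the limit, an expected step of a number no higher from compound 3 to compound 4 (the limit leaves the size open). The estimate for compound 4 is 200000 nM, within 50000 nM to 600000 nM.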

Compound 4, half-maximal inhibitory concentration: > 200000 nM
Compound 4 ended at the assay's limit; the forecaster's own chance of this, stated with the estimate: 60%; the middle value sits exactly at the limit.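

Taking the hydroxymethyl off the saturated chain carbon does not lift compound 4 off the ceiling of this assay, so the hydroxyl group of compound 3 alone does not account for its place there, and two compounds now share one limit, which is not a number: the limit of > 200000 nM in this assay, at which 2 of the 4 values shown sit. The step between compound 3 and compound 4 therefore cannot be read, and the shorter but-1-yn-1-yl chain can be neither ranked against 5-hydroxypent-1-yn-1-yl nor told apart from it. Measured from the other two groups, but-1-yn-1-yl gives an at least 3.1-fold higher number from compound 1 to compound 4 (0.49 log units; beyond the scatter) and an at least 1.8-fold higher number from compound 2 to compound 4 (0.27 log units; that floor lies within the scatter), so only the first of these floors clears the scatter.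

On these data alone, how far either chain lies past the limit stays open. So does whether an amine or a carboxylic acid in place of the hydroxymethyl would give a definite number.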